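Butyl to butylsulfinyl on the shared core

The compounds below may be only part of what the source reports. "The series", "measured", "known", "first", "only" and "open" are said of these compounds alone.

Compound 1 `CCCCc1nc(N)c2nc(O)n(Cc3ccccc3)c2n1`: 0.03 uM
Compound 2 `NNc1nc2c(N)ncnc2n1Cc1ccccc1`: > 10 uM
Compound 3 `Nc1ncnc2c1nc(S)n2Cc1ccccc1`: 10 uM

In a functional assay (spleen, spleen) for activation, with Mus musculus as the target (on this read-out higher numbers stand for an effect only at larger amounts of compound and lower numbers for an effect already at smaller amounts), compound 1 gives 0.03 uM, the lowest of the two numbers shown. Compound 3 gives 10 uM in this assay. For compound 2 only a limit of the assay is recorded, > 10 uM, as the evidence notes (the limit of > 10 uM in this assay, at which 1 of the 3 values shown sits).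

Among the measured compounds shown here, the one measured step joins compound 2 and compound 3: a number no higher from compound 2 to compound 3 (the limit leaves the size open). For the measured compounds named here, it concerns a different place on the shared core and leaves no measured step at the carbon that carries the butyl group of compound 1.

Compound 4 `CCCC[S+]([O-])c1nc(N)c2nc(O)n(Cc3ccccc3)c2n1` differs from compound 1 in one place: a group of 6 heavy atoms (4 carbon, 1 oxygen, 1 sulfur; no ring) in place of a group of 4 heavy atoms (4 carbon; no ring), on an aromatic carbon.

Going by the values given here, no measured step speaks to this change. The expectation therefore rests on the distance of compound 1 from compound 3 and on the untested nature of the new group, and the estimated step is a 10-fold higher number from compound 1 to compound 4 (1.00 log units; beyond the scatter), a rise in the number. For compound 4 the estimated value in this assay is 0.3 uM, with a range from 0.03 uM to 3 uM.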

Compound 4, minimum effective concentration: 0.01 uM
For compound 4 the middle estimate is 30-fold (1.48 log units) above the measured one; the measured number lies below the stated range.
By their numbers in this assay, from the lowest: compound 4; then compound 1; then compound 3.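

In this assay, the butylsulfinyl group on the aromatic carbon between two ring nitrogen atoms gives a 3.0-fold lower number from compound 1 to compound 4 (0.48 log units; beyond the scatter), so at this position the butyl group can be replaced by a group carrying sulfur and oxygen without the number rising. Among the compounds shown here, the step is modest, but it lies beyond the usual scatter, and it is the first step on the shared core whose size can be read: the earlier step lay at a different place and was left open by a limit. Nothing recorded here bears on why the number falls with this change.

A single pair of compounds cannot show whether the lower number goes with the sulfur, with the oxygen or with the larger group as a whole. From the compounds shown here alone, a butylthio group, a butylsulfonyl group, a longer chain or an amine on the same carbon would each test this, and how far the trend from butyl to butylsulfinyl extends remains open.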